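Methyl Replaces Hydrogen on Two Related Fused Cores

The source may hold more compounds than are shown below. What is called first, only, known or untested is meant among the compounds shown, and "the series" means these compounds.

Measured compounds:
compound 1 `O=c1ccc(=O)c2c1c1[nH]c3ccccc3c1c1c(=O)[nH]c(=O)c21` gives 5300 nM in a functional assay on HCT-116 cells (Homo sapiens) for antiproliferative activity, with a stated time of 4 h; a lower number here means a stronger inhibitor, a higher number a weaker inhibitor
compound 2 `Cc1ccc2[nH]c3c4c(=O)ccc(=O)c4c4c(=O)[nH]c(=O)c4c3c2c1` gives 700 nM in this assay
compound 3 `O=C1NC(=O)c2c1c1c(O)ccc(O)c1c1[nH]c3ccccc3c21` gives 3100 nM in this assay

Compound 1 and compound 2 share a core and differ in one place, as described by methyl in place of hydrogen on an aromatic carbon. That single change produced a 7.6-fold lower number from compound 1 to compound 2 (0.88 log units; beyond the scatter). Compound 3 carries a second core; how it differs from the core of compound 1 is not broken down here. In this assay compound 3 stands close to compound 1, their values lying within the usual scatter of each other, while compound 2 sits clearly apart from both.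

Compound 4 `Cc1ccc2[nH]c3c4c(O)ccc(O)c4c4c(c3c2c1)C(=O)NC4=O` is not yet measured. It is built from compound 3 by methyl in place of hydrogen on an aromatic carbon. The description of the place where the methyl enters is the same, word for word, as for the change from compound 1 to compound 2, so this is the same change made on the second core. For compound 4 a step of a 6.2-fold lower number from compound 3 to compound 4 (0.79 log units; beyond the scatter) is expected in this assay, resting on the earlier step of a 7.6-fold lower number from compound 1 to compound 2 (0.88 log units; beyond the scatter) measured on the first core; only one prior example of this change exists among these compounds, so the expectation is held loosely. On that basis compound 4 is estimated at 500 nM, with a likely range from 150 nM to 1600 nM.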

Compound 4, half-maximal inhibitory concentration: 1600 nM
Estimate against measurement, compound 4: 3.2-fold (0.51 log units) below; the measured number falls inside the stated range.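

In this assay, methyl in place of hydrogen on an aromatic carbon of the core of compound 3 gave a 1.9-fold lower number from compound 3 to compound 4 (0.29 log units; within the scatter), so on this core the step does not stand clear of the usual scatter. The change therefore did not carry over from one core to the other with its size intact: the same change on two cores in this assay, a 7.6-fold lower number (0.88 log units; beyond the scatter) from compound 1 to compound 2 and a 1.9-fold lower number (0.29 log units; within the scatter) from compound 3 to compound 4, 3.9-fold (0.59 log units) apart, beyond the scatter of two such steps. This shows that a step measured on the core of compound 1 was not a reliable guide to the size of the step on the core of compound 3, but with a single pair on each core it does not show why the two steps differ, which of them is more typical, or whether the change has any real effect on the core of compound 3.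

The compounds shown leave open whether the gap between the two cores would also appear with other groups at this place, such as an ethyl group, a chlorine atom or an amine. Within the data shown here, they also leave open whether a methyl group on another aromatic carbon of either core would give a step closer to the one from compound 1 or to the one from compound 3.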